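The compounds below may be only part of what the source reports. "The series", "measured", "known", "first", "only" and "open" are said of these compounds alone.

Compound 1, with the structure `O=c1cc(-c2ccccc2)oc2ccc(N3COc4c(cccc4[N+](=O)[O-])C3)cc12`, carries a nitro group on its fused core, and in a functional assay on MCF7 cells (Homo sapiens) for inhibition, read by MTT assay, with a stated time of 48 h, tested at 7.5 ug/mL (on this read-out lower numbers stand for less inhibition of growth and higher numbers for more inhibition of growth at the one concentration tested), compound 1 gives 8.2%. Within the data shown here, the only other compound measured alongside it, compound 2 with the structure `O=c1cc(-c2ccccc2)oc2cc(N3COc4c(Br)cc(Br)cc4C3)ccc12`, gives 1.48% in this assay. Of these two numbers, that of compound 1 is the larger in arithmetic, but the gap to compound 2 lies within the scatter of the assay, so the two compounds cannot be told apart on this read-out, and both sit at the low end of the growth-inhibition scale.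

Compound 3, with the structure `COc1cccc2c1OCN(c1ccc3oc(-c4ccccc4)cc(=O)c3c1)C2`, is the next compound to be tested. It differs from compound 1 in one place: methoxy in place of nitro on an aromatic carbon. Among the measured compounds shown here, no pair of measured compounds shares this exchange, so there is no measured step to lean on. Because compound 1 gives 8.2% and the neighbouring compound 2 gives 1.48%, both low, the exchange is expected to move the number little, and no step beyond the scatter is expected, with a number 1.2 percentage points lower from compound 1 to compound 3 (within the scatter) as the estimated change. Compound 3 is therefore expected to give about 7% in this assay, within a range from 0% to 22%.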

Compound 3, percent growth inhibition at one concentration: 32.5%
Compound 3: middle estimate off by 25.5 percentage points, on the low side, and the stated range ends below it.
By their numbers in this assay, from the lowest: compounds 2 and 1 (each within the scatter of the next); then compound 3.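

In this assay, the aromatic carbon that carries nitro in compound 1 proves sensitive to what sits on it: methoxy in place of nitro gives a number 24.3 percentage points higher from compound 1 to compound 3 (beyond the scatter). Among these compounds, the earlier compounds could not show this, as they differ in more than one place and provided no step, so this is the first single exchange on the shared core whose size can be read, and it lies beyond the usual scatter. No measurement in hand speaks to what lies behind this step.

As far as these compounds go, a single exchange cannot separate a gain that comes with methoxy from one that comes with the loss of nitro, so it remains open whether a hydroxyl, an amine or a longer alkoxy chain such as ethoxy on this same carbon would give a number nearer that of compound 3 or that of compound 1. Also open, from the compounds shown here alone, is whether the step would hold at other concentrations or in other cell lines, and whether methoxy would have a comparable effect on another aromatic carbon of the core.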